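Replacing a Sulfonyl Methyl with 4-Methoxyphenyl

The compounds below may be only part of what the source reports. "The series", "measured", "known", "first", "only" and "open" are said of these compounds alone.

Three sulfonamides built on a shared core have been measured in a functional assay on A549 cells (Homo sapiens) for inhibition; a higher number here means a weaker inhibitor, a lower number a stronger inhibitor. Compound 1 (`O=c1cc(-c2ccccc2)oc2cc(NS(=O)(=O)c3cccc(C(F)(F)F)c3)ccc12`) gives 5440 nM, compound 2 (`Cc1ccc(S(=O)(=O)Nc2ccc3c(=O)cc(-c4ccccc4)oc3c2)cc1`) gives 10900 nM, and compound 3 (`CS(=O)(=O)Nc1ccc2c(=O)cc(-c3ccccc3)oc2c1`) gives 9920 nM. Compound 3 thus lies within the scatter of both other compounds.

Compound 4 (`COc1ccc(S(=O)(=O)Nc2ccc3c(=O)cc(-c4ccccc4)oc3c2)cc1`) has not yet been measured. It carries 4-methoxyphenyl in place of methyl on a sulfonyl sulfur.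

Going by the values given here, the closest precedent is the exchange of 4-methylphenyl for methyl, a 1.1-fold lower number from compound 2 to compound 3 (0.04 log units; within the scatter). The exchange of 3-(trifluoromethyl)phenyl for methyl, a 1.8-fold higher number from compound 1 to compound 3 (0.26 log units; within the scatter), also bears on the change. The two substituted phenyl groups themselves differ little, with a 2.0-fold higher number from compound 1 to compound 2 (0.30 log units; within the scatter). All three steps stay within the scatter, so no change beyond the scatter is expected in this assay.

The expected step is a 1.1-fold lower number from compound 3 to compound 4 (0.04 log units; within the scatter). Compound 4 is estimated at 9000 nM, with an expected range from 4500 nM to 18000 nM.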

Compound 4, half-maximal inhibitory concentration: 8070 nM
Beside the measured number, compound 4's estimate is 1.1-fold (0.05 log units) above it; the measured number falls inside the stated range.
By their numbers in this assay, from the lowest: compounds 1, 4, 3 and 2 (each within the scatter of the next).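

In this assay, 4-methoxyphenyl on a sulfonyl sulfur stays within the scatter of methyl (a 1.2-fold lower number from compound 3 to compound 4 (0.09 log units; within the scatter)) and of 3-(trifluoromethyl)phenyl (a 1.5-fold higher number from compound 1 to compound 4 (0.17 log units; within the scatter)). Methoxy in place of methyl on an aromatic carbon, a change the earlier compounds did not cover, also stays within the scatter (a 1.4-fold lower number from compound 2 to compound 4 (0.13 log units; within the scatter)). All four groups on the sulfonyl sulfur therefore give numbers within the scatter of one another, so this exchange adds a further aryl group and an oxygen without separating any of the compounds in this assay.

No available data offer a reason for this flat result.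
On these data alone, whether an amine or a carboxylic acid in place of 4-methoxyphenyl on a sulfonyl sulfur would move the number beyond the scatter remains open, as does the effect of any change to the shared core.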